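The source may report more compounds than this note shows. Statements on the series, on what has been measured and on what is new or still open speak of the compounds shown alone.

Within the data shown here, compound 3 `O=C([C@H]1C[C@@H]1F)N1CC2CC(C1)N2` sits second highest of the three numbers so far in an assay on SH-EP1 cells for agonist activity at Neuronal acetylcholine receptor; alpha4/beta2 (Homo sapiens), read by FLIPR and calcium flux (a lower number here means a smaller maximal response, a higher number a larger maximal response), where compound 3 gives 100%. Its nearest neighbour is compound 1 `CC(=O)N1CC2CC(C1)N2`, which in this assay gives 94%, and the step of a number 6 percentage points higher from compound 1 to compound 3 (within the scatter). Compound 2 `O=C([C@H]1C[C@H]1F)N1CC2CC(C1)N2` gives 110%, and the step of a number 10 percentage points lower from compound 2 to compound 3 (within the scatter); the two differ only in one drawn configuration (the fact that one of compounds 2 and 3 is drawn with a defined configuration and the other without, at the place where they differ). Compound 4 `C[C@H]1C[C@H]1C(=O)N1CC2CC(C1)N2` differs from compound 3 by 2-methylcyclopropyl in place of 2-fluorocyclopropyl on a carbonyl carbon. Both earlier changes on that carbonyl carbon moved the number little: the step of a number 16 percentage points higher from compound 1 to compound 2 (beyond the scatter) and the step of a number 6 percentage points higher from compound 1 to compound 3 (within the scatter). A change of similar kind is therefore expected to give no step beyond the scatter, so compound 4 is estimated at 100%, between 85% and 115%, a step of no change at the digits printed from compound 3 to compound 4 (within the scatter).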

Compound 4, largest response reached (Emax), in percent of the reference or control that the assay uses: 87%
Beside the measured number, compound 4's estimate is 13 percentage points above it; low and high end bracket the measured number.
By their numbers in this assay, from the lowest: compounds 4, 1, 3 and 2 (each within the scatter of the next, the first and the last beyond it).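

Putting 2-methylcyclopropyl in place of 2-fluorocyclopropyl on this carbonyl carbon brings the first fall beyond the scatter at this position, with a number 13 percentage points lower from compound 3 to compound 4 (beyond the scatter) and a number 23 percentage points lower from compound 2 to compound 4 (beyond the scatter) as the two steps. So the atom on the small ring can matter, yet a number 7 percentage points lower from compound 1 to compound 4 (within the scatter) shows that the methyl-bearing ring cannot be told apart from plain methyl. Nothing given here explains the difference between the fluorine and methyl versions. Still open, as far as these compounds go, is how the other configurations of 2-methylcyclopropyl would read, and what a longer chain or a carboxylic acid on that carbonyl carbon would do.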